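A few compounds are considered here, and "the series" means these few. Any claim that something is new, unique, unknown or untested is made for them only; others in the source may bear on it.

Compound 1 `COc1cc(-c2nn(-c3ccccc3)cc2C(=O)/C=C\Nc2ccc(F)cc2)cc(OC)c1OC`: 7700 nM
Compound 2 `COc1ccc(N/C=C\C(=O)c2cn(-c3ccccc3)nc2-c2cc(OC)c(OC)c(OC)c2)cc1`: 9600 nM

In a functional assay on PC-3 cells (Homo sapiens) for antiproliferative activity, read by MTT assay, with a stated time of 48 h (on this read-out lower numbers stand for stronger inhibition and higher numbers for weaker inhibition), compound 2 is one of two measured compounds, and a 1.2-fold higher number from compound 1 to compound 2 (0.10 log units; within the scatter) places it within the scatter of compound 1. Compound 3 `COc1cc(N/C=C\C(=O)c2cn(-c3ccccc3)nc2-c2cc(OC)c(OC)c(OC)c2)cc(OC)c1OC` differs from compound 2 by 3,4,5-trimethoxyphenyl in place of 4-methoxyphenyl on an amine nitrogen. Going by the values given here, no measured step touches that place; the only step known, from fluoro to methoxy on an aromatic carbon, stayed within the scatter, so nothing suggests a change beyond the scatter in this assay. Compound 3 is therefore expected near 9000 nM, between 4000 nM and 25000 nM, a step of a 1.1-fold lower number from compound 2 to compound 3 (0.03 log units; within the scatter).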

Compound 3, half-maximal inhibitory concentration: 14100 nM
Compound 3: the middle estimate sits 1.6-fold (0.19 log units) below what was measured; low and high end bracket the measured number.
By their numbers in this assay, from the lowest: compounds 1, 2 and 3 (each within the scatter of the next).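

In this assay, the place on the amine nitrogen also takes 3,4,5-trimethoxyphenyl, with 12 heavy atoms instead of 8, and a 1.5-fold higher number from compound 2 to compound 3 (0.17 log units; within the scatter) and a 1.8-fold higher number from compound 1 to compound 3 (0.26 log units; within the scatter) both stay within the scatter. This read-out therefore cannot separate the three groups tried on this nitrogen, even though the fluoro and methoxy groups are now joined by a larger group.

Going by these compounds, whether a phenyl ring carrying a carboxylic acid or an amine, or a saturated ring such as cyclohexyl, would move the number remains open. No measurement offered here accounts for this result.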